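Replacing a cyano-bearing pyrazole with a difluoromethyl-bearing one

The compounds below may be only part of what the source reports. "The series", "measured", "known", "first", "only" and "open" are said of these compounds alone.

Compound 1, `Cc1cc(-c2c(C)nn(C)c2C)ccc1-c1nnc(N(C)Cc2ccc3nccn3c2)o1`, gives 3.7 in a physicochemical assay for lipophilicity, at pH 7.4; a lower number here means a more polar compound, a higher number a more lipophilic compound.
Compound 2, `Cc1cc(-c2c(C)n[nH]c2C)ccc1-c1nnc(N(C)Cc2ccc3nccn3c2)o1`, gives 3.8 in this assay.
Compound 3, `Cc1cc(-c2c(C#N)nn(C)c2C)ccc1-c1nnc(N(C)Cc2ccc3nccn3c2)o1`, gives 3.4 in this assay.

Compound 3 stands apart from compound 2 by a number 0.40 log units lower from compound 2 to compound 3 (beyond the scatter), but the step of a number 0.30 log units lower from compound 1 to compound 3 (within the scatter) is within the scatter and does not separate those two. Compound 4, `Cc1cc(-c2c(C)nn(C(F)F)c2C)ccc1-c1nnc(N(C)Cc2ccc3nccn3c2)o1`, has not yet been measured. The change is 1-(difluoromethyl)-3,5-dimethyl-1H-pyrazol-4-yl in place of 3-cyano-1,5-dimethyl-1H-pyrazol-4-yl on an aromatic carbon. Going by the values given here, two measured steps bear on it. The step of a number 0.30 log units lower from compound 1 to compound 3 (within the scatter) is the reverse of the cyano-for-methyl part of this change, so undoing it should return roughly to the number of compound 1. The step of a number 0.10 log units higher from compound 1 to compound 2 (within the scatter) shows that swapping a group on the aromatic nitrogen of the pyrazole did little. Among the compounds with values here, no measured pair shows a difluoromethyl entering on that nitrogen, so that part of the change rests on no direct evidence here. In this assay compound 4 is therefore expected at 4, between 3.6 and 4.4, an estimated step of a number 0.60 log units higher from compound 3 to compound 4 (beyond the scatter) upward from compound 3.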

Compound 4, distribution coefficient: 4.1
The estimate for compound 4 lay 0.10 log units below the measured number; the measured number falls inside the stated range.
By their numbers in this assay, from the lowest: compounds 3, 1, 2 and 4 (each within the scatter of the next, the first and the last beyond it).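

On the aromatic nitrogen of the pyrazole, difluoromethyl in place of methyl gives a number 0.40 log units higher from compound 1 to compound 4 (beyond the scatter) in this assay and so provides a change at this nitrogen that clears the scatter, while difluoromethyl in place of hydrogen gives a number 0.30 log units higher from compound 2 to compound 4 (within the scatter) and leaves the two compounds unseparated. The full exchange of one substituted pyrazole for the other gives a number 0.70 log units higher from compound 3 to compound 4 (beyond the scatter) and is the widest step among the compounds shown. Nothing measured here accounts for the size of these steps.

As far as these compounds go, whether a trifluoromethyl or an ethyl group on that nitrogen would give a number like that of compound 4 remains open. So does the effect of difluoromethyl on the pyrazole carbon that carries the nitrile in compound 3.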